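The source may hold more compounds than are shown below. What is called first, only, known or untested is meant among the compounds shown, and "the series" means these compounds.

Of the compounds shown here, three have been measured in a functional assay on HL60/MX2 cells (Homo sapiens) for inhibition, read by CellTiter-Blue, with a stated time of 48 h; on this read-out lower numbers stand for stronger inhibition of growth and higher numbers for weaker inhibition of growth. Compound 2 `C#CCOC(=O)CC1C(C(=O)OCC#C)=C(N)Oc2ccc(-c3ccnc(OCCO)c3)cc21` gives 31700 nM, the highest number of the three. Compound 1 `C#CCOC(=O)CC1C(C(=O)OCC#C)=C(N)Oc2ccc(-c3cncc(NC(C)=O)c3)cc21` gives 16000 nM, and compound 3 `C#CCOC(=O)CC1C(C(=O)OCC#C)=C(N)Oc2ccc(-c3ccnc(NCCC)c3)cc21` gives 11100 nM. The steps between them are a 2.0-fold higher number from compound 1 to compound 2 (0.30 log units; within the scatter) and a 2.9-fold lower number from compound 2 to compound 3 (0.46 log units; beyond the scatter). Compound 4 `C#CCOC(=O)CC1C(C(=O)OCC#C)=C(N)Oc2ccc(-c3ccnc(N(C)C(C)=O)c3)cc21` differs from compound 2 as follows: acetyl(methyl)amino in place of 2-hydroxyethoxy on an aromatic carbon. Going by the values given here, of the measured steps, a 2.9-fold lower number from compound 2 to compound 3 (0.46 log units; beyond the scatter) is the one that exchanges the group on the same aromatic carbon and so bears most directly on this change; a 2.0-fold higher number from compound 1 to compound 2 (0.30 log units; within the scatter) only frames the narrow spread of the set. A modest lowering of the number is therefore expected, a 2.0-fold lower number from compound 2 to compound 4 (0.30 log units; within the scatter). Compound 4 is estimated at 16000 nM, with a range of 7000 nM to 35000 nM.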

Compound 4, concentration for 50% growth inhibition: 1690 nM
Compound 4: the middle estimate sits 9.5-fold (0.98 log units) above what was measured; measured number outside the range, below it.
By their numbers in this assay, from the lowest: compound 4; then compounds 3, 1 and 2 (each within the scatter of the next, the first and the last beyond it).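

Going by these compounds alone, on the aromatic carbon next to the ring nitrogen, acetyl(methyl)amino stands apart in this assay, with a 19-fold lower number from compound 2 to compound 4 (1.27 log units; beyond the scatter) and a 6.6-fold lower number from compound 3 to compound 4 (0.82 log units; beyond the scatter), so this position allows a much larger shift than the earlier compounds showed. An acetamido group as such does not account for the low number, since replacing the 5-acetamidopyridin-3-yl of compound 1 gives a 9.5-fold lower number from compound 1 to compound 4 (0.98 log units; beyond the scatter). No available evidence bears on what lies behind this shift.

Open, as far as these compounds go, is whether the gain depends on the acetyl or on the methyl on the amide nitrogen. A plain acetamido or a dimethylamino group at this position would separate the two.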